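Ester series: a methyl added to compound 2

The source may report more compounds than this note shows. Statements on the series, on what has been measured and on what is new or still open speak of the compounds shown alone.

compound 1 `CNC(=O)c1cc(Oc2ccc3cc(C(=O)OC)sc3c2)ccn1`: 68300 nM
compound 2 `CNC(=O)c1cc(Oc2ccc3cc(C(=O)OC(C)C)sc3c2)ccn1`: 45000 nM

Within the data shown here, in an ADME assay on HeLa cells (Homo sapiens) for cytotoxicity, read by MTT assay, with a stated time of 2 days (a lower number here means that less compound is tolerated, a higher number that more compound is tolerated), compound 2 stands within the scatter of the only other measured compound, and the single measured step is a 1.5-fold lower number from compound 1 to compound 2 (0.18 log units; within the scatter). Compound 3 `CNC(=O)c1cc(Oc2ccc3c(C)c(C(=O)OC(C)C)sc3c2)ccn1` carries methyl in place of hydrogen on an aromatic carbon of the shared core: methyl in place of hydrogen on an aromatic carbon. The measured step changes the ester group, not this carbon, so it bears on the change only loosely. With so little evidence, no step beyond the scatter is expected. The estimated step is a 1.1-fold lower number from compound 2 to compound 3 (0.05 log units; within the scatter). For compound 3 the expected value is 40000 nM, with an estimated range of 16000 nM to 90000 nM.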

Compound 3, half-maximal cytotoxic concentration: 9600 nM
The estimate for compound 3 lay 4.2-fold (0.62 log units) above the measured number; measured number below the stated range.
By their numbers in this assay, from the lowest: compound 3; then compounds 2 and 1 (each within the scatter of the next).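

In this assay, the aromatic carbon next to the ring atom that bears an isopropoxycarbonyl group responds to a single added methyl, giving a 4.7-fold lower number from compound 2 to compound 3 (0.67 log units; beyond the scatter). Among these compounds, the earlier ester change stayed within the scatter, so this is the first position where the number clearly moves. Nothing measured here accounts for the step.

Open, as far as these compounds go, is whether ethyl or an amine on this carbon would move the number further. Also open, from the compounds shown here alone, is whether the added methyl gives a similar step on the methyl ester, compound 1.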